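A few compounds are considered here, and "the series" means these few. Any claim that something is new, unique, unknown or untested is made for them only; others in the source may bear on it.

Measured in a physicochemical assay for solubility, read by LC-MS, in phosphate buffer, with a stated time of 24 h, at pH 7.4; a lower number here means a less soluble compound, a higher number a more soluble compound:
Compound 1 `Cc1nccn1-c1cnc(NCc2c(F)ccc3c2CCO3)c2cn[nH]c(=O)c12`: 7000 nM
Compound 2 `Cc1nc(CO)ccc1-c1cnc(NCc2c(F)ccc3c2CCO3)c2cn[nH]c(=O)c12`: 3000 nM
Compound 3 `CC(=O)N1CCC(c2cnc(NCc3c(F)ccc4c3CCO4)c3cn[nH]c(=O)c23)CC1`: < 2000 nM (a limit, not a number)

Compound 3 therefore stands on a limit only. Compound 4 `Cc1nc(CN(C)C)ccc1-c1cnc(NCc2c(F)ccc3c2CCO3)c2cn[nH]c(=O)c12` gives up its 1-acetylpiperidin-4-yl for 6-((dimethylamino)methyl)-2-methylpyridin-3-yl: 6-((dimethylamino)methyl)-2-methylpyridin-3-yl in place of 1-acetylpiperidin-4-yl on an aromatic carbon. The nearest measured group is the 6-(hydroxymethyl)-2-methylpyridin-3-yl of compound 2, which reads 3000 nM. Swapping that group for 1-acetylpiperidin-4-yl gave an at least 1.5-fold lower number from compound 2 to compound 3 (0.17 log units; that floor lies within the scatter), a floor within the scatter. The other two steps are modest: a 2.3-fold lower number from compound 1 to compound 2 (0.37 log units; beyond the scatter) and an at least 3.5-fold lower number from compound 1 to compound 3 (0.54 log units; beyond the scatter). A modest rise in this assay is thus expected, running back towards compound 2. The expected step is an at least 2.5-fold higher number from compound 3 to compound 4 (0.39 log units; beyond the scatter). For compound 4 the estimate is 5000 nM, with an expected range of 2000 nM to 20000 nM.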

Compound 4, solubility: > 1000000 nM
Compound 4 ended at the assay's limit; the forecaster's own chance of this, stated with the estimate: 12%; at least 200-fold (2.30 log units) between middle value and limit.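

In this assay, for the compounds shown here, the one change of dimethylamino in place of hydroxy on the chain carbon gives an at least 330-fold higher number from compound 2 to compound 4 (2.52 log units; beyond the scatter), so this small edit on the 2-methylpyridin-3-yl group moves the read-out far more than the modest earlier steps did. Against the other two groups at this position, the new group gives an at least 500-fold higher number from compound 3 to compound 4 (2.69 log units; beyond the scatter) and an at least 140-fold higher number from compound 1 to compound 4 (2.15 log units; beyond the scatter). Compound 4 stands on a limit, not a number, so all three steps are floors: the limit of > 1000000 nM in this assay, at which 1 of the 4 values shown sits.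

As far as these compounds go, whether dimethylamino itself is needed stays open, since a primary amine, a pyrrolidine or a carboxylic acid on that chain carbon could behave differently. From the compounds shown here alone, how far compound 4 lies past its limit also stays open.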